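The source may report more compounds than this note shows. Statements on the series, on what has been measured and on what is new or still open speak of the compounds shown alone.

Measured so far:
Compound 1 `O=C(/C(=C\c1ccc(O)cc1)SCc1ccc(Cl)cc1)c1ccc(Br)cc1` gives 10000 nM in a functional assay on DU-145 cells (Homo sapiens) for inhibition, read by trypan blue exclusion, with a stated time of 96 h; a higher number here means a weaker inhibitor of growth, a lower number a stronger inhibitor of growth.
Compound 2 `COc1ccc(/C=C(/SCc2ccc(Cl)cc2)C(=O)c2ccc(Br)cc2)cc1` gives 10000 nM in this assay.
Compound 3 `Cc1ccsc1/C=C(/SCc1ccc(F)cc1)C(=O)c1ccc(Br)cc1` gives 50000 nM in this assay.

Compound 3 therefore stands with the highest number of the three, beyond the scatter from both compound 1 and compound 2, so it is the weakest inhibitor of growth among them. Compound 4 `Cc1ccsc1/C=C(/SCc1ccc(Cl)cc1)C(=O)c1ccc(Br)cc1` differs from compound 3 by chloro in place of fluoro on an aromatic carbon. Within the data shown here, the only measured step, no change at the digits printed from compound 1 to compound 2 (within the scatter), concerns a different change on a different ring and does not bear on this exchange; no measured pair shows chloro in place of fluoro. Among the measured compounds shown here, with no direct precedent, no step beyond the scatter is expected in this assay. Compound 4 is expected to give about 40000 nM, between 15000 nM and 100000 nM, an estimated 1.3-fold lower number from compound 3 to compound 4 (0.10 log units; within the scatter).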

Compound 4, concentration for 50% growth inhibition: 25000 nM
For compound 4 the middle estimate is 1.6-fold (0.20 log units) above the measured one; the measured number falls inside the stated range.
By their numbers in this assay, from the lowest: compounds 1 and 2 (each within the scatter of the next); then compounds 4 and 3 (each within the scatter of the next).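

In this assay the exchange of fluoro for chloro on this six-membered ring gives a 2.0-fold lower number from compound 3 to compound 4 (0.30 log units; within the scatter) and so shows no clear effect at this position. With chloro held in place, 3-methylthiophen-2-yl in place of the other aromatic groups gives a modest rise in the number, seen as a 2.5-fold higher number from compound 2 to compound 4 (0.40 log units; beyond the scatter) and as a 2.5-fold higher number from compound 1 to compound 4 (0.40 log units; beyond the scatter). No measurement shown explains these steps. Still open, from the compounds shown here alone, is whether a different kind of group at this position, such as an amine or a carboxylic acid, would move the number beyond the scatter.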